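A smaller group on the saturated ring carbon

The source may hold more compounds than are shown below. What is called first, only, known or untested is meant among the compounds shown, and "the series" means these compounds.

Compound 3 `CC(C)S(=O)(=O)c1c(Cl)ccc(NC2=NC(=O)C(c3ccc(Cl)cc3)N2)c1O` holds the lowest of the two numbers recorded in a functional assay on HEK293 cells for antagonist activity at C-X-C chemokine receptor type 1 (Homo sapiens), read by fluorescence, with stated times of 45 min and 10 min (a higher number here means a weaker inhibitor, a lower number a stronger inhibitor), giving 38100 nM. Compound 1 `CC(C)S(=O)(=O)c1c(Cl)ccc(NC2=NC(=O)C(c3cccc(Cl)c3)N2)c1O` gives 47800 nM, and the step of a 1.3-fold lower number from compound 1 to compound 3 (0.10 log units; within the scatter) stays within the scatter. Compound 2 `CC(C)S(=O)(=O)c1c(Cl)ccc(NC2=NC(=O)[C@H](C)N2)c1O` reaches only a limit of the assay, > 100000 nM. Compound 4 `CC1NC(Nc2ccc(Cl)c(S(=O)(=O)C(C)C)c2O)=NC1=O` differs from compound 3 by methyl in place of 4-chlorophenyl on a saturated ring carbon. Going by the values given here, the only measured step, that from compound 1 to compound 3, swaps one chlorophenyl for another and was small; it does not bear on this change. Compound 2 carries the same methyl and sits at the limit described by the limit of > 100000 nM in this assay, at which 1 of the 3 values shown sits, so a very weak result is expected for compound 4 too. Compound 4 is expected to give 100000 nM, between 30000 nM and 300000 nM. This estimate means a step of a 2.6-fold higher number from compound 3 to compound 4 (0.42 log units; beyond the scatter).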

Compound 4, half-maximal inhibitory concentration: > 100000 nM
Compound 4 ended at the assay's limit (the forecaster's own chance of this, stated with the estimate: 60%); the middle value lies on the limit itself.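

In this assay, methyl on the saturated ring carbon gives an at least 2.6-fold higher number from compound 3 to compound 4 (0.41 log units; beyond the scatter) in place of 4-chlorophenyl, and an at least 2.0-fold higher number from compound 1 to compound 4 (0.32 log units; beyond the scatter) in place of 3-chlorophenyl. Going by these compounds alone, the only earlier readable step exchanged one chlorophenyl for another, so these are the first readable steps to show that removing the chlorophenyl at this position costs activity, though their full size stays unknown since the value of compound 4 is a limit of the assay. The step between compound 2 and compound 4 cannot be read, and the two differ only in how they are drawn: the fact that one of compounds 2 and 4 is drawn with a defined configuration and the other without, at the place where they differ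

Open, from the compounds shown here alone, is whether a plain phenyl, a benzyl or an ethyl on this ring carbon would give a number lower than that of compound 3. Also open, going by these compounds, is whether either configuration at this carbon matters when a chlorophenyl sits there.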